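The source may report more compounds than this note shows. Statements on the series, on what has been measured and on what is new or still open speak of the compounds shown alone.

Series notes, cytotoxicity set. Three compounds carry a value in a functional assay on MCF7 cells (Homo sapiens) for cytotoxicity, read by MTT assay, with a stated time of 72 h, tested at 3 uM; a higher number here means more inhibition of growth at the concentration tested, a lower number less inhibition of growth. Compound 1 `N/C(=N\NC(=S)N1CCCCCC1)c1ccccn1` gives 56%. Compound 2 `N/C(=N\NC(=S)N1CCOCC1)c1ccccn1` gives 44.5%. Compound 3 `Cc1cccc(/C(N)=N/NC(=S)N2CCOCC2)n1` gives 21.6%. Compound 1 stands highest of the three, its steps to both others beyond the scatter; the difference between its core and the core of compound 2 is not broken down here, and the two values simply show compound 2 lower than compound 1.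

Compound 2 and compound 3 differ in one place, (methyl in place of hydrogen on an aromatic carbon). That change made a number 22.9 percentage points lower from compound 2 to compound 3 (beyond the scatter), a modest drop.

Compound 4 `Cc1cccc(/C(N)=N/NC(=S)N2CCCCCC2)n1` is not yet measured. It differs from compound 1 by methyl in place of hydrogen on an aromatic carbon, the same kind of change as that between compound 2 and compound 3, with the place described in the same words. Going by the values given here, only one earlier instance of this change exists, so the expectation rests on that single step applied to the value of compound 1, 56%.

Compound 4 is expected to show a step of about a number 23 percentage points lower from compound 1 to compound 4 (beyond the scatter) in this assay because of a number 22.9 percentage points lower from compound 2 to compound 3 (beyond the scatter). Compound 4 is therefore estimated at 33%, within 18% to 48%.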

Compound 4, percent growth inhibition at one concentration: 15.7%
Compound 4: the middle estimate sits 17.3 percentage points above what was measured; the whole stated range lies above it.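

In this assay, methyl in place of hydrogen on an aromatic carbon again lowers the number on the second core, with a number 40.3 percentage points lower from compound 1 to compound 4 (beyond the scatter), so the direction of the step carries from one core to the other in this pair. The size does not carry over, and the two instances differ by more than the scatter allows: the same change on two cores in this assay, a number 22.9 percentage points lower (beyond the scatter) from compound 2 to compound 3 and a number 40.3 percentage points lower (beyond the scatter) from compound 1 to compound 4, 17.4 percentage points apart, beyond the scatter of two such steps. This shows that, across these four compounds, the size of the step cannot be taken unchanged from one core to the other, but two instances neither explain the gap nor show how large the step would be on any further core.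

The compounds shown leave open whether an ethyl group, a chlorine atom or a methoxy group in the same place would lower the number as methyl does. They also leave open how the same change would behave with a dimethylamino group in place of the ring that differs between compound 1 and compound 2.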